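Working notes: three limits and one untested chloro analogue

This account rests on a few compounds, and the source may have more. Where it says the series, first, only, none or still open, it means among the compounds named here.

Measured so far, all in a functional assay on Bel-7402 cells (Homo sapiens) for cytotoxicity, read by MTT assay; on this read-out higher numbers stand for weaker inhibition and lower numbers for stronger inhibition:
Compound 1 `Cc1ccc(Nc2nc(C)c(C(=O)/C=C/c3ccc(Cl)cc3)s2)cc1`: compound 1 gives > 25000 nM, a limit of the assay.
Compound 2 `Cc1nc(Nc2cccc(Cl)c2)sc1C(=O)/C=C/c1ccccc1`: compound 2 gives > 25000 nM, a limit of the assay.
Compound 3 `Cc1ccc(Nc2nc(C)c(C(=O)/C=C/c3ccccc3Cl)s2)cc1`: compound 3 gives > 25000 nM, a limit of the assay.

Going by the values given here, compound 1 has no position on a numerical scale: its result is a limit, and every value so far sits at the same limit (the limit of > 25000 nM in this assay, at which 3 of the 3 values shown sit). Among the compounds with values here, the only single-point comparison, a step that the two limits leave unreadable from compound 1 to compound 3, is unreadable because both ends are limits, so it tells nothing about the size or direction of any change. Within the data shown here, no measured step in this set therefore carries information that bears on a further modification.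

Compound 4 `Cc1nc(Nc2ccc(Cl)cc2)sc1C(=O)/C=C/c1ccc(Cl)cc1` is the next analogue. Relative to compound 1 the change is chloro in place of methyl on an aromatic carbon, on the aromatic carbon of the six-membered aromatic ring of carbon only, para to a large group; cut one bond further out it reads 4-methylphenyl to 4-chlorophenyl, or (4-methylphenyl)amino to (4-chlorophenyl)amino.

With every measured compound at the limit of > 25000 nM in this assay, at which 3 of the 3 values shown sit, and no readable step, no direction can be expected beyond the scatter. Compound 4 is estimated at 35000 nM, with a range from 12000 nM to 120000 nM, most probably reported again as a limit. The step that the limit leaves unreadable from compound 1 to compound 4 is expected to stay within the usual scatter.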

Compound 4, half-maximal inhibitory concentration: > 25000 nM
Compound 4: only a limit was reported; the forecaster's own chance of this, stated with the estimate: 75%; the middle value lies beyond the limit too.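

In this assay compound 4 gives > 25000 nM as a limit of the assay. No step can be read from compound 1 to compound 4, since both results are limits and the series offers no number to compare: the limit of > 25000 nM in this assay, at which 4 of the 4 values shown sit.

The compounds shown leave open whether any change to the shared core brings a value within the measurable range.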